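The compounds below may be only part of what the source reports. "The series", "measured", "known", "first", "only" and "open" are said of these compounds alone.

In a functional assay on A2780 cells (Homo sapiens) for cytotoxicity, read by sulforhodamine B assay, with a stated time of 72 h (on this read-out lower numbers stand for stronger inhibition and higher numbers for weaker inhibition), compound 1 (`O=C(NCc1ccc(S(=O)(=O)C2CCN(C3COC3)CC2)cc1)N1Cc2ccncc2C1`) gives 7.4 nM and compound 2 (`CN1CCN(S(=O)(=O)c2ccc(CNC(=O)N3Cc4ccncc4C3)cc2)CC1`) gives 71 nM, so compound 2 holds the higher, weaker number of the pair. Compound 3 (`O=C(NCc1ccc(S(=O)(=O)N2CC3(CCOCC3)C2)cc1)N1Cc2ccncc2C1`) shares its core and differs in one group on the sulfonyl sulfur: a group of 9 heavy atoms (7 carbon, 1 nitrogen, 1 oxygen; one four-membered non-aromatic ring with 1 hetero atom, one six-membered non-aromatic ring with 1 hetero atom) in place of a group of 7 heavy atoms (5 carbon, 2 nitrogen; one six-membered non-aromatic ring with 2 hetero atoms), on a sulfonyl sulfur. Among the compounds with values here, only one measured step bears on this, a 9.6-fold higher number from compound 1 to compound 2 (0.98 log units; beyond the scatter), a modest change at that same place, and it suggests that compound 2 can be improved there. A somewhat smaller move toward a lower number is expected, a 3.6-fold lower number from compound 2 to compound 3 (0.55 log units; beyond the scatter). For compound 3 the estimated value is 20 nM, with an expected range of 6 nM to 70 nM.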

Compound 3, half-maximal inhibitory concentration: 10 nM
Estimate against measurement, compound 3: 2.0-fold (0.30 log units) above; measured number inside the range.
By their numbers in this assay, from the lowest: compounds 1 and 3 (each within the scatter of the next); then compound 2.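

A second group on the sulfonyl sulfur now beats 4-methylpiperazin-1-yl, with a 7.1-fold lower number from compound 2 to compound 3 (0.85 log units; beyond the scatter). Compound 3 keeps a ring nitrogen on the sulfur, as compound 2 does, so a low number does not require the ring carbon attached there in compound 1. The two groups with a four-membered and a six-membered ring are not separated, with a 1.4-fold higher number from compound 1 to compound 3 (0.13 log units; within the scatter).

On these data alone, whether an open-chain dimethylamino group at this place would keep the number low remains open. Nothing available explains why 4-methylpiperazin-1-yl gives the weaker number.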